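This account rests on a few compounds, and the source may have more. Where it says the series, first, only, none or still open, it means among the compounds named here.

The measured compounds:
Compound 1, `Nc1sc(-c2ccccc2)c(-c2ccc(Cl)cc2)c1C(=O)N1CCCC1`: in a functional assay on PC-3 cells (Homo sapiens) for cytotoxicity, read by sulforhodamine B assay, with a stated time of 72 h (a lower number here means a stronger inhibitor, a higher number a weaker inhibitor), compound 1 gives 22200 nM.
Compound 2, `Nc1sc(-c2ccc([N+](=O)[O-])cc2)c(-c2ccc(Cl)cc2)c1C(=O)NC1CC1`: for compound 2 the result in this assay is "not determined" (no result reported).
Compound 3, `O=C1CC(c2ccccc2)c2c(sc(-c3ccc(Cl)cc3)c2-c2ccc(Cl)cc2)N1`: compound 3 reaches only the limit of this assay, > 50000 nM, which is a limit and not a number.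

Compound 3 therefore stands at the edge of what this assay can report, as the limit of > 50000 nM in this assay, at which 1 of the 3 values shown sits, records, while compound 1 is the only one of the three with a single number. Compound 4, `O=C1CC(c2cccs2)c2c(sc(-c3ccc(Cl)cc3)c2-c2ccc(Cl)cc2)N1`, has not yet been measured in this assay. It differs from compound 3 in one place: thiophen-2-yl in place of phenyl on a saturated ring carbon. Going by the values given here, no pair of measured compounds here differs in a single place, so no measured step can guide the expectation. Given that compound 3 sits at the limit > 50000 nM, the step from compound 3 to compound 4 is expected to stay within the usual scatter, with no direction beyond it, most likely ending at the limit again; the expected step is a number no higher from compound 3 to compound 4 (the limit leaves the size open). The estimate for compound 4 is 50000 nM, within a range of 20000 nM to 120000 nM.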

Compound 4, half-maximal inhibitory concentration: > 50000 nM
Compound 4: no number, only a limit (the forecaster's own chance of this, stated with the estimate: 70%); the middle value lies on the limit itself.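

Compound 3 and compound 4 both reach only a limit of this assay, not a number, so no new step can be read between them: the limit of > 50000 nM in this assay, at which 2 of the 4 values shown sit.

The compounds shown leave open whether thiophen-2-yl in place of phenyl on a saturated ring carbon changes the read-out at all.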